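The source may report more compounds than this note shows. Statements on the series, on what has been measured and on what is new or still open speak of the compounds shown alone.

The measured compounds:

Compound 1, `CNC(=O)c1ccc(-c2ccc(Cl)cc2)c(COc2ccc(-c3nc4cc(C(=O)O)ccc4n3C3CCCCC3)cc2)c1`: in a functional assay on Huh-5-2 cells (Homo sapiens), read by MTT assay (a higher number here means that more compound is tolerated, a lower number that less compound is tolerated), compound 1 gives 25000 nM.
Compound 2, `CN(C)C(=O)c1ccc(-c2ccc(Cl)cc2)c(COc2ccc(-c3nc4cc(C(=O)O)ccc4n3C3CCCCC3)cc2)c1`: compound 2 gives 28000 nM.
Compound 3, `CC(=O)Nc1ccc(-c2ccc(Cl)cc2)c(COc2ccc(-c3nc4cc(C(=O)O)ccc4n3C3CCCCC3)c(F)c2)c1`: compound 3 gives 24000 nM.

Compound 1 and compound 2 share one core and differ in a single place, (methyl in place of hydrogen on an amide-type nitrogen). That change made a 1.1-fold higher number from compound 1 to compound 2 (0.05 log units; within the scatter), so the two values show no real difference. Compound 3 stands on a different core; the difference between the cores of compound 3 and compound 1 is not broken down here. The values of compound 3 and compound 1 lie within the scatter of each other, as do those of compound 3 and compound 2.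

Compound 4, `CC(=O)N(C)c1ccc(-c2ccc(Cl)cc2)c(COc2ccc(-c3nc4cc(C(=O)O)ccc4n3C3CCCCC3)c(F)c2)c1`, has not yet been measured. It differs from compound 3 by methyl in place of hydrogen on an amide-type nitrogen. This is the same kind of change as that from compound 1 to compound 2, not the same one: in compound 1 the amide-type nitrogen's other neighbours are a carbonyl carbon and a saturated chain carbon, while in compound 3 they are an aromatic carbon and a carbonyl carbon.

Given that one observed methyl-for-hydrogen step, the expected step from compound 3 to compound 4 is a 1.1-fold higher number from compound 3 to compound 4 (0.03 log units; within the scatter), resting on a 1.1-fold higher number from compound 1 to compound 2 (0.05 log units; within the scatter). The estimated value for compound 4 is therefore 26000 nM, expected to fall between 13000 nM and 52000 nM.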

Compound 4, half-maximal cytotoxic concentration: 26000 nM
Beside the measured number, compound 4's estimate shows no gap at the digits printed, within the range that was stated.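

In this assay the methyl in place of hydrogen on the amide-type nitrogen gave a 1.1-fold higher number from compound 3 to compound 4 (0.03 log units; within the scatter) and so no real difference, and the same change on the other core compares closely: the same change on two cores in this assay, a 1.1-fold higher number (0.05 log units; within the scatter) from compound 1 to compound 2 and a 1.1-fold higher number (0.03 log units; within the scatter) from compound 3 to compound 4, 1.0-fold (0.01 log units) apart, within the scatter of two such steps. The change therefore carried over between these two cores without a real difference in either pair, even though the nitrogen has different neighbours in each: a carbonyl carbon and a saturated chain carbon in compound 1, an aromatic carbon and a carbonyl carbon in compound 3. Two pairs do not make a general rule, however, and they do not show that the change would behave the same way on a third core or in any other test.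

The compounds shown leave open what a larger group on that nitrogen, such as an ethyl or a longer chain, would do to the tolerated concentration. They also leave open whether a plain amine in place of the amide would give a number like these.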